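Adding a Methoxy Group to an Inactive Phenyl Analogue

The source may report more compounds than this note shows. Statements on the series, on what has been measured and on what is new or still open speak of the compounds shown alone.

Compound 2 `CCOC(=O)c1cnc2scc(-c3ccccc3)n12` carries a phenyl group on the shared core. In an assay on isolated protein for inhibition of Indoleamine 2,3-dioxygenase 1 (Homo sapiens), with a stated time of 30 min (a lower number here means a stronger inhibitor, a higher number a weaker inhibitor), compound 2 gives > 100000 nM, which is a limit of the assay and not a number. Compound 1 `CCOC(=O)c1cnc2scc(C3=CCCCC3)n12` in this assay gives > 100000 nM, likewise a limit. The step that the two limits leave unreadable from compound 1 to compound 2 cannot be read, as the limit of > 100000 nM in this assay, at which 2 of the 2 values shown sit, shows. Compound 3 `CCOC(=O)c1cnc2scc(-c3ccc(OC)cc3)n12` differs from compound 2 by methoxy in place of hydrogen on an aromatic carbon. For the measured compounds named here, no measured step bears on this change, so no shift beyond the scatter is expected in this assay. For compound 3 the step is expected to be a number no higher from compound 2 to compound 3 (the limit leaves the size open). Compound 3 is estimated at 100000 nM, between 30000 nM and 300000 nM.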

Compound 3, half-maximal inhibitory concentration: 56000 nM
For compound 3 the middle estimate is 1.8-fold (0.25 log units) above the measured one; the measured number falls inside the stated range.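

Methoxy in place of hydrogen, para to a large group, brings compound 3 to a measured number in this assay, 56000 nM, the only one of the three values that is not a limit. The change gives an at least 1.7-fold lower number from compound 2 to compound 3 (0.25 log units; that floor lies within the scatter), so it cannot yet be called a real gain. Its true size stays open because compound 2 sits at a limit: the limit of > 100000 nM in this assay, at which 2 of the 3 values shown sit.

The compounds shown leave open whether an amine or a carboxylic acid in place of the methoxy would bring the number lower.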